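The source may report more compounds than this note shows. Statements on the series, on what has been measured and on what is new or still open speak of the compounds shown alone.

Of the compounds shown here, two of a shared core have been measured in an ADME assay on the whole organism with Oryza sativa as the target, tested at 10 uM; a higher number here means a weaker effect of the compound at the concentration tested, a lower number a stronger effect. Compound 1, `CC(C)c1ccc(NC(=O)N[C@@H](C)c2ccccc2)cc1`, gives 86% in this assay. Among the measured compounds shown here, compound 2, `CCCCc1ccc(NC(=O)N[C@@H](C)c2ccccc2)cc1`, gives 60% in this assay, and it stands as the lower of the two numbers, the only step measured so far being a number 26 percentage points lower from compound 1 to compound 2 (beyond the scatter). Compound 3, `C[C@H](NC(=O)Nc1ccc(C(F)(F)F)cc1)c1ccccc1`, has not yet been measured in this assay. It differs from compound 2 in one place: trifluoromethyl in place of butyl on an aromatic carbon. For the measured compounds named here, the one measured step shows that exchanging the group on this aromatic carbon does move the read-out beyond the scatter, yet that step concerned butyl replacing isopropyl, and no measured compound carries trifluoromethyl, so the direction for compound 3 is open. A change back toward the value of compound 1 is as plausible as none; compound 3 is therefore expected to show a number 15 percentage points higher from compound 2 to compound 3 (beyond the scatter), with an estimate of 75% and a range from 50% to 95%.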

Compound 3, a percentage reported as activity, at one concentration (the size of the read-out at that concentration, not a potency): 94%
Compound 3: middle estimate off by 19 percentage points, on the low side; the range from low to high includes it.
By their numbers in this assay, from the lowest: compound 2; then compounds 1 and 3 (each within the scatter of the next).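

Putting trifluoromethyl on this aromatic carbon in place of butyl gives a number 34 percentage points higher from compound 2 to compound 3 (beyond the scatter) in this assay, while putting it there in place of isopropyl gives a number 8 percentage points higher from compound 1 to compound 3 (within the scatter). Among these three groups, only butyl sets its compound apart, with the stronger effect; butyl and trifluoromethyl each hold 4 heavy atoms, yet their compounds lie far apart, so heavy-atom count alone does not sort these results. No measurement at hand explains why the butyl compound stands apart.

The compounds shown leave open whether the stronger effect follows the straight carbon chain, and a propyl or pentyl chain in the same place would test that. They also leave open how a group of another kind, such as an amine or a carboxylic acid, would behave on this aromatic carbon.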